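Replacing cyclohexyl with methyl in compound 2

A few compounds are considered here, and "the series" means these few. Any claim that something is new, unique, unknown or untested is made for them only; others in the source may bear on it.

Of the compounds shown here, three have been measured in a functional assay on HT-29 cells (Homo sapiens) for inhibition, read by sulforhodamine B assay, with a stated time of 48 h; on this read-out higher numbers stand for weaker inhibition of growth and lower numbers for stronger inhibition of growth. There, compound 1 (`c1ccc2cc(NC3=NCCO3)ccc2c1`) gives 2000 nM and compound 2 (`O=C(CCl)NC(=O)Nc1ccc(C2CCCCC2)cc1`) gives 2300 nM while compound 3 (`O=C(CCl)NC(=O)Nc1cccc(OC2CCCC2)c1`) gives 3100 nM in the same test. All three values lie within the scatter of one another, so compound 2 stands level with the other two and no order can be drawn among them.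

Compound 4 (`Cc1ccc(NC(=O)NC(=O)CCl)cc1`) has methyl in place of cyclohexyl on an aromatic carbon of compound 2 (methyl in place of cyclohexyl on an aromatic carbon). Among the measured compounds shown here, no two measured compounds differ in one place, so no measured step serves as a guide. The expectation rests only on this structural change to compound 2 at 2300 nM and is therefore uncertain. In this assay the expected step is a 3.5-fold higher number from compound 2 to compound 4 (0.54 log units; beyond the scatter) toward a higher number and weaker inhibition of growth, modestly beyond the scatter. For compound 4 the expected value is 8000 nM within an estimated range from 3000 nM to 25000 nM overall.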

Compound 4, concentration for 50% growth inhibition: 10000 nM
The estimate for compound 4 lay 1.3-fold (0.10 log units) below the measured number, within the range that was stated.
By their numbers in this assay, from the lowest: compounds 1, 2 and 3 (each within the scatter of the next); then compound 4.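

In this assay the step between the only two compounds shown that differ in one place is a 4.3-fold higher number from compound 2 to compound 4 (0.64 log units; beyond the scatter) and so the group on this aromatic carbon, para to a group of 8 heavy atoms, bears on the read-out: with methyl in place of cyclohexyl, inhibition of growth is weaker. The earlier compounds shown here could not show this, since no two of them differ in one place and their values lie within the scatter of one another. Nothing measured here accounts for the step.

The compounds shown leave open whether the cyclohexyl ring itself matters, or whether an open hexyl chain on this carbon would serve as well. They also leave open how a phenyl group, an amine or a carboxylic acid would read at the same place.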